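Swapping chloro for bromo on a hydroxamic acid series

A few compounds are considered here, and "the series" means these few. Any claim that something is new, unique, unknown or untested is made for them only; others in the source may bear on it.

Measured compounds:
- compound 1, `O=C(CCCCCCN1C(=O)/C(=N\O)c2cc(Cl)ccc21)NO`: 680 nM
- compound 2, `O=C(CCCCCCN1C(=O)/C(=N\O)c2cc(Br)ccc21)NO`: 1770 nM
- compound 3, `CO/N=C1/C(=O)N(CCCCCCC(=O)NO)c2ccc(Cl)cc21`: 1560 nM

These three compounds were tested in a functional assay on MCF7 cells (Homo sapiens) for antiproliferative activity, read by sulforhodamine B assay, with a stated time of 48 h; a lower number here means a stronger inhibitor, a higher number a weaker inhibitor. Compound 1 and compound 2 share one core; compound 3 carries a different core, and the difference between the two cores is not broken down here. In this assay compound 1 gives 680 nM, while compound 2 gives 1770 nM; the change between them is bromo in place of chloro on an aromatic carbon, and its step is a 2.6-fold higher number from compound 1 to compound 2 (0.42 log units; beyond the scatter). Compound 3 gives 1560 nM in this assay, a number close to that of compound 2 and further from that of compound 1.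

The unmeasured compound 4, `CO/N=C1/C(=O)N(CCCCCCC(=O)NO)c2ccc(Br)cc21`, is related to compound 3 exactly as compound 2 is related to compound 1: the change is bromo in place of chloro on an aromatic carbon, at the same place as before. Going by the values given here, only one earlier example of this change is available, so the expectation leans on that single step. Compound 4 is expected to show a step of a 2.6-fold higher number from compound 3 to compound 4 (0.41 log units; beyond the scatter) in this assay, because the same change gave a 2.6-fold higher number from compound 1 to compound 2 (0.42 log units; beyond the scatter). On this basis the estimated value for compound 4 in this assay is 4000 nM, with a range from 1500 nM to 10000 nM.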

Compound 4, half-maximal inhibitory concentration: 7790 nM
Compound 4: the middle estimate sits 1.9-fold (0.29 log units) below what was measured; low and high end bracket the measured number.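

In this assay, the new step is a 5.0-fold higher number from compound 3 to compound 4 (0.70 log units; beyond the scatter), so bromo in place of chloro on an aromatic carbon again gives a higher number, which here means a weaker inhibitor, just as it did on the first core. The direction of the change carries over from one core to the other, and the two steps cannot be told apart in size, even though the second looks larger on paper: the same change on two cores in this assay, a 2.6-fold higher number (0.42 log units; beyond the scatter) from compound 1 to compound 2 and a 5.0-fold higher number (0.70 log units; beyond the scatter) from compound 3 to compound 4, 1.9-fold (0.28 log units) apart, within the scatter of two such steps. Going by these compounds alone, this is still only two matched pairs in a single cell assay, so it does not show that the step would hold on any further core, and it does not explain why a bromo compound gives a higher number than its chloro partner.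

The compounds shown leave open how fluoro, iodo, methyl or a plain hydrogen at this same place would compare with chloro and bromo, since only these two groups can be set side by side here. They also leave open whether the step would keep its direction with a shorter or longer chain leading to the hydroxamic acid, or with an ethyl group in place of the methyl on the oxime oxygen.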